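Carbamate for Amide on the Pyrazole Amine

The source may report more compounds than this note shows. Statements on the series, on what has been measured and on what is new or still open speak of the compounds shown alone.

Among the compounds with values here, the three compounds measured so far share one core and differ only at the amide-bearing carbon. Compound 1 `Cc1cc(C(=O)Nc2ccccn2)nn1Cc1cc(Cl)ccc1OCc1ccccc1` gives 126 nM in an assay on CHO-K1 cells for displacement of a labelled ligand from prostaglandin E2 receptor EP1 subtype (Homo sapiens) (on this read-out higher numbers stand for weaker inhibition and lower numbers for stronger inhibition), compound 2 `Cc1cc(C(=O)NCc2cccnc2)nn1Cc1cc(Cl)ccc1OCc1ccccc1` gives 50.1 nM, and compound 3 `Cc1cc(NC(=O)C(C)C)nn1Cc1cc(Cl)ccc1OCc1ccccc1` gives 25.1 nM. Compound 3 carries the lowest of the three numbers; its nearest neighbour is compound 2, a 2.0-fold lower number from compound 2 to compound 3 (0.30 log units; within the scatter), and its furthest is compound 1, a 5.0-fold lower number from compound 1 to compound 3 (0.70 log units; beyond the scatter).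

Compound 4 `Cc1cc(NC(=O)OC(C)(C)C)nn1Cc1cc(Cl)ccc1OCc1ccccc1` keeps the reversed amide of compound 3 and changes only the acyl end: tert-butoxy in place of isopropyl on a carbonyl carbon. Within the data shown here, none of the measured steps touches this position; the steps of a 2.5-fold lower number from compound 1 to compound 2 (0.40 log units; beyond the scatter) and a 5.0-fold lower number from compound 1 to compound 3 (0.70 log units; beyond the scatter) each alter the whole amide group rather than the substituent on the carbonyl carbon, so they give no direct guide. Without any step bearing on the change, the expected step is a 1.0-fold lower number from compound 3 to compound 4 (0.00 log units; within the scatter), which lies within the scatter. Compound 4 is therefore estimated at 25 nM, with a range from 10 nM to 63 nM.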

Compound 4, half-maximal inhibitory concentration: 25.1 nM
Beside the measured number, compound 4's estimate is 1.0-fold (0.00 log units) below it, within the range that was stated.
By their numbers in this assay, from the lowest: compounds 3, 4 and 2 (each within the scatter of the next); then compound 1.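

At the carbonyl carbon of the reversed amide, tert-butoxy in place of isopropyl leaves the number in this assay in the same place (no change at the digits printed from compound 3 to compound 4 (within the scatter)), so this position takes the larger group, with its added oxygen, without a visible shift. The (tert-butoxycarbonyl)amino group also stands level with the ((pyridin-3-yl)methyl)carbamoyl group (a 2.0-fold lower number from compound 2 to compound 4 (0.30 log units; within the scatter)), and it holds the same gap to the (pyridin-2-yl)carbamoyl group that the (isopropylcarbonyl)amino group showed (a 5.0-fold lower number from compound 1 to compound 4 (0.70 log units; beyond the scatter)). Nothing measured here gives a reason for these numbers.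

The compounds shown leave open how far this carbonyl carbon accepts other groups, such as a methoxy, a benzyloxy or a longer alkyl chain. They also leave open whether an amine on the same carbonyl carbon would stay level with compound 3 and compound 4.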